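Aryl variation at the shared core: toward compound 3

The compounds below may be only part of what the source reports. "The series", "measured", "known", "first", "only" and "open" are said of these compounds alone.

Going by the values given here, compound 2 `O=C(O)CCC(=O)N1N=C(c2c(-c3cccc(C(F)(F)F)c3)c3ccccc3[nH]c2=O)CC1c1ccc(Cl)cc1` is one of two compounds measured in an assay on cells (Oocyte) for negative allosteric modulation of glutamate receptor ionotropic, NMDA 2D (Rattus norvegicus), read by two-electrode voltage clamp; on this read-out higher numbers stand for weaker inhibition and lower numbers for stronger inhibition. In that assay compound 2 gives 2600 nM, the highest of the two numbers seen so far; its nearest neighbour is compound 1 `Cc1ccc(-c2c(C3=NN(C(=O)CCC(=O)O)C(c4ccc(Cl)cc4)C3)c(=O)[nH]c3ccccc23)cc1`, which gives 1400 nM, and the two values lie within the scatter of one another. Among the compounds with values here, the only step documented is a 1.9-fold higher number from compound 1 to compound 2 (0.27 log units; within the scatter), an exchange of the aryl group at the same position that is varied here.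

Compound 3 `O=C(O)CCC(=O)N1N=C(c2c(-c3ccc(Cl)c(Cl)c3)c3ccccc3[nH]c2=O)CC1c1ccc(Cl)cc1` has not yet been measured. It differs from compound 2 by 3,4-dichlorophenyl in place of 3-(trifluoromethyl)phenyl on an aromatic carbon. Within the data shown here, the single step that bears on this change, a 1.9-fold higher number from compound 1 to compound 2 (0.27 log units; within the scatter), also swapped one aryl group for another at this position and stayed within the scatter, so no step beyond the scatter is expected in this assay from compound 2 to compound 3, in either direction. Compound 3 is therefore expected to give about 2200 nM, with a range from 800 nM to 6000 nM. Among the measured compounds shown here, the expected step is a 1.2-fold lower number from compound 2 to compound 3 (0.07 log units; within the scatter); this rests on one pair only, and a doubly substituted ring at this position has no precedent among the measured compounds.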

Compound 3, half-maximal inhibitory concentration: 910 nM
Estimate against measurement, compound 3: 2.4-fold (0.38 log units) above; the measured number falls inside the stated range.
By their numbers in this assay, from the lowest: compounds 3, 1 and 2 (each within the scatter of the next, the first and the last beyond it).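

In this assay, this aromatic carbon now gives its first step beyond the scatter, a 2.9-fold lower number from compound 2 to compound 3 (0.46 log units; beyond the scatter), so the exchange of 3-(trifluoromethyl)phenyl for 3,4-dichlorophenyl moves the number, though only modestly. The same entering group in place of 4-methylphenyl gives a 1.5-fold lower number from compound 1 to compound 3 (0.19 log units; within the scatter), which stays within the scatter, so only compound 2 and compound 3 are separated among the three aryl groups, and compound 1 cannot be ordered against either. The doubly substituted ring therefore shows no loss of inhibition against either singly substituted ring, but nothing measured here explains the step between compound 2 and compound 3.

The compounds shown leave open whether both chlorines are needed for this step, a question that 3-chlorophenyl and 4-chlorophenyl at the same carbon would address. They also leave open how an aryl ring bearing an amine or a carboxylic acid would read in this assay, since the three aryl groups here carry only methyl, trifluoromethyl or chlorine.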